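A few compounds are considered here, and "the series" means these few. Any claim that something is new, unique, unknown or untested is made for them only; others in the source may bear on it.

Measured compounds:

- Compound 1, `Cc1cc(C)c(S(=O)(=O)N2CCN(C3CN4CCC3CC4)CC2)c(C)c1`: in an ADME assay on HCT-116 cells (Homo sapiens) for cytotoxicity, read by CellTiter-Glo, with a stated time of 72 h (on this read-out higher numbers stand for weaker inhibition and lower numbers for stronger inhibition), compound 1 gives > 5000 nM, which is a limit of the assay and not a number.
- Compound 2, `CC1CCN(C2CCN(S(=O)(=O)c3ccc(Cl)cc3Cl)CC2)CC1`: in this assay compound 2 gives > 5000 nM, again a limit.
- Compound 3, `Cc1cc(C)c(S(=O)(=O)N2CCC(N3CCC(c4ccccc4)CC3)CC2)c(C)c1`: in this assay compound 3 gives > 5000 nM, also a limit.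

All three measured compounds therefore sit at the same point, (the limit of > 5000 nM in this assay, at which 3 of the 3 values shown sit), so none of them can be ranked against another, and compound 3 stands at that limit like the rest. Within the data shown here, no step between measured compounds is available.

Compound 4, `C#CCCC(=O)CC1CCN(C2CCN(S(=O)(=O)c3c(C)cc(C)cc3C)CC2)CC1`, differs from compound 3 in one place: ((but-3-yn-1-yl)carbonyl)methyl in place of phenyl on a saturated ring carbon. Among the measured compounds shown here, with every measured value a limit, there is no measured step to lean on. The expectation is that the step that the limit leaves unreadable from compound 3 to compound 4 stays at or near the limit, in no direction beyond the scatter. Compound 4 is therefore estimated at 8000 nM, with a range from 3000 nM to 30000 nM, and most likely the assay will again report only a limit.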

Compound 4, half-maximal inhibitory concentration: > 5000 nM
Compound 4: only a limit was reported; the forecaster's own chance of this, stated with the estimate: 80%; the middle value is on the limit's open side.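

In this assay, compound 3 and compound 4 each give only a limit, so no step can be read between them: the limit of > 5000 nM in this assay, at which 4 of the 4 values shown sit.

The compounds shown leave open whether ((but-3-yn-1-yl)carbonyl)methyl in place of phenyl changes the result in this assay at all, and what structure would give a real number there.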